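The source may hold more compounds than are shown below. What is called first, only, known or untested is meant among the compounds shown, and "the series" means these compounds.

Measured compounds:
compound 1, `Cc1n[nH]cc1-c1cccc2c1CCC2c1ncc[nH]1`, 3 nM
compound 2, `COc1c(C)ccc2c1CCC2c1ncc[nH]1`, 167 nM
compound 3, `CCCS(=O)(=O)Nc1cccc2c1CCC2c1ncc[nH]1`, 1340 nM

These three compounds share a core and were tested in a functional assay on CHO cells for agonist activity at Alpha-1A adrenergic receptor (Homo sapiens), read by FLIPR and calcium flux; on this read-out higher numbers stand for an effect only at larger amounts of compound and lower numbers for an effect already at smaller amounts. Compound 1 gives the lowest number of the three; compound 2 lies at 167 nM, and compound 3 is furthest away at 1340 nM.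

The new compound 4, `c1cc(-c2ccn[nH]2)c2c(c1)C(c1ncc[nH]1)CC2`, differs from compound 1 in one place: 1H-pyrazol-5-yl in place of 3-methyl-1H-pyrazol-4-yl on an aromatic carbon. The group that leaves and the group that enters are both a five-membered aromatic ring with two hetero atoms, each carrying one hydrogen-bond donor and one hydrogen-bond acceptor.

Going by the values given here, the only measured step at this position is a 450-fold higher number from compound 1 to compound 3 (2.65 log units; beyond the scatter), where the pyrazole was replaced by a group of a quite different kind. Compound 4 keeps a pyrazole, so a change of that size is not expected; a modest rise in the number is the more likely outcome, with a 3.3-fold higher number from compound 1 to compound 4 (0.52 log units; beyond the scatter) expected. For compound 4 the estimate is 10 nM, in the range 2 nM to 60 nM.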

Compound 4, half-maximal effective concentration: 52 nM
Compound 4: middle estimate off by 5.2-fold (0.72 log units), on the low side; the measured number falls inside the stated range.
By their numbers in this assay, from the lowest: compound 1; then compound 4; then compound 2; then compound 3.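

In this assay this position proves sensitive even to a close replacement: 1H-pyrazol-5-yl in place of 3-methyl-1H-pyrazol-4-yl gives a 17-fold higher number from compound 1 to compound 4 (1.24 log units; beyond the scatter) even though both groups are five-membered aromatic rings with 2 hetero atoms and the same counts of hydrogen-bond donors and acceptors. The identity of the group still matters in the other direction, as 1H-pyrazol-5-yl in place of (propylsulfonyl)amino gives a 26-fold lower number from compound 3 to compound 4 (1.41 log units; beyond the scatter) and so recovers much of the gap between those groups. No measurement at hand explains the difference between the two pyrazoles.

The step combines the loss of the methyl with a change in how the ring is attached, and a 1H-pyrazol-4-yl group without the methyl would separate the two. On these data alone, how a simple amine or a carboxylic acid would fare on this aromatic carbon remains open.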